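The source may report more compounds than this note shows. Statements on the series, on what has been measured and on what is new or still open speak of the compounds shown alone.

Working notes on the series, read in a physicochemical assay for lipophilicity; on this read-out lower numbers stand for lower lipophilicity and higher numbers for higher lipophilicity. Compound 1 `CCCCCCNC(=O)c1ccc(S(N)(=O)=O)cc1` gives 2.05 and compound 2 `CCCCCCCNC(=O)c1ccc(S(N)(=O)=O)cc1` gives 2.57. Compound 3 `CCCOC(=O)c1cccc(S(N)(=O)=O)c1` gives 1.72, the lowest of the three numbers and beyond the scatter from both others.

The next compound is compound 4 `CCCCCOC(=O)c1cccc(S(N)(=O)=O)c1`, which has not been measured. Its change from compound 3 is ethyl in place of hydrogen on a saturated chain carbon, three bonds along the chain from an oxygen next to a carbonyl group. In words, this is ethyl in place of hydrogen on a saturated chain carbon, three bonds along the chain from an oxygen next to a carbonyl group, and the same difference reads propyl to pentyl.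

Among the measured compounds shown here, only one measured step bears on this: a number 0.52 log units higher from compound 1 to compound 2 (beyond the scatter). That modest step is a methyl in place of hydrogen on a chain running from an amide-type nitrogen, so it is a chain extension on a different chain. For the measured compounds named here, no measured step exists on the chain of compound 3, which makes the transfer uncertain. Here an ethyl enters rather than a methyl, so a larger step in the same direction is expected in this assay.

The expected step is a number 1.03 log units higher from compound 3 to compound 4 (beyond the scatter), beyond the scatter. Compound 4 is estimated at 2.75, with an expected range of 2.35 to 3.1.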

Compound 4, partition coefficient: 2.71
Compound 4: middle estimate off by 0.04 log units, on the high side, within the range that was stated.
By their numbers in this assay, from the lowest: compound 3; then compound 1; then compounds 2 and 4 (each within the scatter of the next).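

In this assay the ethyl on a saturated chain carbon, three bonds along the chain from an oxygen next to a carbonyl group, gives a number 0.99 log units higher from compound 3 to compound 4 (beyond the scatter) and provides the first step read on this chain. The only earlier step, a number 0.52 log units higher from compound 1 to compound 2 (beyond the scatter) for a methyl on a chain running from an amide-type nitrogen, lies in the same direction, so both steps shown for added chain carbons raise the number and neither pair goes against this. Nothing available explains the size of either step or shows what sets this chain's response apart from that of the other chain.

Still open, on these data alone, is whether a longer chain in place of the ethyl would keep raising the number at this place or whether the rise would level off. Also open is whether an amine or a carboxylic acid in place of the ethyl would move the number in the same direction, since both steps shown involve only saturated chain groups.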